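Swapping Amino for Piperazin-1-yl on Compound 2

The compounds below may be only part of what the source reports. "The series", "measured", "known", "first", "only" and "open" are said of these compounds alone.

In a functional assay on NCI-H1581 cells (Homo sapiens) for antiproliferative activity, read by CCK-8 assay, with a stated time of 72 h (a higher number here means a weaker inhibitor, a lower number a stronger inhibitor), compound 1 `COc1cc(OC)c(Cl)c(-c2ccc3c(NC(=O)c4ccc(N5CCN(C)CC5)s4)n[nH]c3n2)c1Cl` gives 3.7 nM, while compound 2 `COc1cc(OC)c(Cl)c(-c2ccc3c(NC(=O)c4ccc(N)cc4)n[nH]c3n2)c1Cl` gives 218 nM, the higher of the two numbers. Compound 3 `COc1cc(OC)c(Cl)c(-c2ccc3c(NC(=O)c4ccc(N5CCNCC5)cc4)n[nH]c3n2)c1Cl` carries piperazin-1-yl in place of amino on an aromatic carbon, para to a large group: piperazin-1-yl in place of amino on an aromatic carbon. Among the measured compounds shown here, only one measured step bears on this change, and it is large: a 59-fold higher number from compound 1 to compound 2 (1.77 log units; beyond the scatter). That step exchanges the whole group on the carbonyl carbon, so it is only an indirect guide. Compound 3 regains a six-membered non-aromatic ring with 2 hetero atoms but keeps the six-membered aromatic ring of compound 2. Part of the gap behind a 59-fold higher number from compound 1 to compound 2 (1.77 log units; beyond the scatter) is therefore expected to close, giving a clear step toward a lower number in this assay. The expected change is an 8.7-fold lower number from compound 2 to compound 3 (0.94 log units; beyond the scatter). For compound 3, the estimated value is 25 nM, with an expected range from 6 nM to 100 nM.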

Compound 3, half-maximal inhibitory concentration: 1.4 nM
Estimate against measurement, compound 3: 18-fold (1.25 log units) above, and the stated range ends above it.
By their numbers in this assay, from the lowest: compound 3; then compound 1; then compound 2.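

In this assay, the aromatic carbon para to a large group proves highly sensitive to what it carries: piperazin-1-yl in place of amino gives a 160-fold lower number from compound 2 to compound 3 (2.19 log units; beyond the scatter), and this step isolates the change in a way the earlier pair could not. The six-membered aromatic ring of carbon only therefore does not by itself hold a compound at a high number, as a 2.6-fold lower number from compound 1 to compound 3 (0.42 log units; beyond the scatter) leaves compound 3 with the lowest number of the three. No measurement shown here offers an explanation for the size of this step.

The compounds shown leave open how much of the step rests on the ring and how much on its second nitrogen, which a morpholin-4-yl or dimethylamino group at this place would address. The contributions of the aromatic ring and the methyl on the piperazine also stay unseparated, since both differ together between compound 1 and compound 3.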